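From 2-chlorophenyl to 3-cyanophenyl: notes on the series

The source may hold more compounds than are shown below. What is called first, only, known or untested is meant among the compounds shown, and "the series" means these compounds.

Of the compounds shown here, two have been measured so far. In a functional assay on MIA PaCa-2 cells (Homo sapiens) for inhibition, read by MTT assay, with a stated time of 72 h, tested at 30 uM (on this read-out higher numbers stand for more inhibition of growth at the one concentration tested and lower numbers for less inhibition of growth), compound 1 (`C=CCc1cc(O)c(O)c(CN2CCC(CCO)CC2)c1`) gives 54.4% and compound 2 (`C=CCc1ccc(OCc2cn(-c3ccccc3Cl)nn2)c(O)c1`) gives 46.6%. These two values lie within the scatter of each other, so compound 2 stands level with compound 1 on the present numbers.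

Compound 3 (`C=CCc1ccc(OCc2cn(-c3cccc(C#N)c3)nn2)c(O)c1`) keeps the rest of compound 2 and carries 3-cyanophenyl in place of 2-chlorophenyl on an aromatic nitrogen of a five-membered aromatic ring with 3 nitrogen: 3-cyanophenyl in place of 2-chlorophenyl on an aromatic nitrogen. For the measured compounds named here, no measured pair shows a change of this kind, so the expectation rests only on compound 2 at 46.6%. No step beyond the scatter is expected in this assay, and the estimated change is a number 1.6 percentage points lower from compound 2 to compound 3 (within the scatter). For compound 3 the expected value is 45%, with an estimated range from 30% to 60%.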

Compound 3, percent growth inhibition at one concentration: 26.6%
For compound 3 the middle estimate is 18.4 percentage points above the measured one; the whole stated range lies above it.
By their numbers in this assay, from the lowest: compound 3; then compounds 2 and 1 (each within the scatter of the next).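

In this assay, 3-cyanophenyl in place of 2-chlorophenyl on an aromatic nitrogen gives a number 20 percentage points lower from compound 2 to compound 3 (beyond the scatter), so the group at this position can move the read-out beyond the scatter. The entering group adds a nitrile and one hydrogen-bond acceptor, but 2-chlorophenyl and 3-cyanophenyl differ both in the group carried and in where it stands on the phenyl ring, and this single pair cannot separate the two. No measurement at hand accounts for the step.

Open, going by these compounds, is where 2-cyanophenyl and 3-chlorophenyl would fall relative to compound 2 and compound 3, which would separate the group from its place. Also open, on these data alone, is how unsubstituted phenyl, or a phenyl ring carrying an amine or a carboxylic acid, would read at this nitrogen.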